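From Azido to Hydroxy on a Shared Core

A few compounds are considered here, and "the series" means these few. Any claim that something is new, unique, unknown or untested is made for them only; others in the source may bear on it.

In a functional assay on MCF7 cells (Homo sapiens) for antiproliferative activity, read by MTT assay, with stated times of 24 h and 72 h (on this read-out lower numbers stand for stronger inhibition and higher numbers for weaker inhibition), compound 1 `COc1cc(N2C(=O)[C@@H](Oc3ccccc3)[C@H]2c2ccc([N+](=O)[O-])cc2)cc(OC)c1OC`, which carries a nitro group, gives 63000 nM. For the measured compounds named here, compound 2 `COc1cc(N2C(=O)[C@@H](Oc3ccccc3)[C@H]2c2ccc(N=[N+]=[N-])cc2)cc(OC)c1OC` gives 23000 nM, the lower of the two numbers measured so far. Going by the values given here, only one measured step bears on the next change: a 2.7-fold lower number from compound 1 to compound 2 (0.44 log units; beyond the scatter). This replacement of nitro by azido on an aromatic carbon is modest in size but lies beyond the scatter.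

Compound 3 `COc1cc(N2C(=O)[C@@H](Oc3ccccc3)[C@H]2c2ccc(O)cc2)cc(OC)c1OC` keeps the core of compound 2 and has hydroxy in place of azido on an aromatic carbon, para to a large group: hydroxy in place of azido on an aromatic carbon. In other words, 4-azidophenyl becomes 4-hydroxyphenyl. Among the compounds with values here, no measured compound carries the hydroxy group, so the data offer no direct guide to this change. Within the data shown here, the single earlier step at this place, a 2.7-fold lower number from compound 1 to compound 2 (0.44 log units; beyond the scatter), is the only yardstick for size. A change of similar modest size is therefore expected in this assay, leaning tentatively towards a lower number. The estimated step is a 1.9-fold lower number from compound 2 to compound 3 (0.28 log units; within the scatter). For compound 3 the estimated value is 12000 nM, with an expected range from 2500 nM to 55000 nM.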

Compound 3, half-maximal inhibitory concentration: 48000 nM
Beside the measured number, compound 3's estimate is 4.0-fold (0.60 log units) below it, within the range that was stated.
By their numbers in this assay, from the lowest: compound 2; then compounds 3 and 1 (each within the scatter of the next).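

In this assay, the azido group now stands apart from both other groups at this place on the shared core. The step of a 2.1-fold higher number from compound 2 to compound 3 (0.32 log units; beyond the scatter) is modest but beyond the scatter, and hydroxy, which brings a hydrogen-bond donor and replaces three heavy atoms with one, does not carry over what azido gave, so compound 2 keeps the lowest number of the three. Hydroxy and nitro cannot be told apart, since the step of a 1.3-fold lower number from compound 1 to compound 3 (0.12 log units; within the scatter) lies within the scatter, and no measurement at hand explains why azido differs from these two groups.

The compounds shown leave open whether an amine or a fluorine atom at the same place would match azido, fall level with hydroxy and nitro, or give a lower number than any of the three. They also leave open whether the gap between azido and hydroxy would persist if another part of the shared core were changed, as all three compounds share everything but this one group.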